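The source may hold more compounds than are shown below. What is called first, only, known or untested is meant among the compounds shown, and "the series" means these compounds.

The measured compounds:
Compound 1 `COc1ccc(C(=O)/C=C/c2ccc(-n3ccnc3)cc2)c2c1C=CC(C)(C)O2` gives > 10000 nM in a functional assay on SW-620 cells (Homo sapiens) for antiproliferative activity, read by MTT assay, with a stated time of 24 h (a higher number here means a weaker inhibitor, a lower number a stronger inhibitor), which is a limit of the assay.
Compound 2 `COc1ccc(C(=O)/C=C/c2ccc([N+](=O)[O-])cc2)c2c1C=CC(C)(C)O2` gives 3520 nM in this assay.
Compound 3 `COc1ccc(C(=O)/C=C/c2ccc(C(F)(F)F)cc2)c2c1C=CC(C)(C)O2` gives > 10000 nM in this assay, which is a limit of the assay.

Going by the values given here, compound 2 thus holds the only actual number; the other two values are limits (the limit of > 10000 nM in this assay, at which 2 of the 3 values shown sit). Compound 4 `COc1ccccc1/C=C/C(=O)c1ccc(OC)c2c1OC(C)(C)C=C2` differs from compound 2 in one place: 2-methoxyphenyl in place of 4-nitrophenyl on a double-bonded chain carbon bound to a double-bonded chain carbon. Among the compounds with values here, two measured steps bear on this change, an at least 2.8-fold lower number from compound 1 to compound 2 (0.45 log units; beyond the scatter) and an at least 2.8-fold higher number from compound 2 to compound 3 (0.45 log units; beyond the scatter): in each, the nitro compound carries the number, and exchanging the nitro group for another leaves only a limit. Compound 4 exchanges the whole aryl group, so a weakening step is expected: a 3.4-fold higher number from compound 2 to compound 4 (0.53 log units; beyond the scatter). Compound 4 is therefore expected to give about 12000 nM, within 3000 nM to 50000 nM, and quite possibly only a limit.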

Compound 4, half-maximal inhibitory concentration: > 10000 nM
Compound 4: only a limit was reported (the forecaster's own chance of this, stated with the estimate: 60%); the middle value does not contradict the limit.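

The change gives an at least 2.8-fold higher number from compound 2 to compound 4 (0.45 log units; beyond the scatter), so replacing 4-nitrophenyl with 2-methoxyphenyl also loses the measurable activity, just as the two earlier exchanges did. The value of compound 4, > 10000 nM, is a limit of the assay and not a number. Among the compounds shown, 4-nitrophenyl alone gives an actual number at this place, and the others stop at one shared limit: the limit of > 10000 nM in this assay, at which 3 of the 4 values shown sit.

Differences among compound 1, compound 3 and compound 4 cannot be read from their limits. On these data alone, whether a phenyl ring carrying an amine or a carboxylic acid would give a number remains open.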